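The compounds below may be only part of what the source reports. "The series", "measured", "known", "first", "only" and "open" are said of these compounds alone.

Compound 1 `O=C(Nc1ccccc1Br)N[C@H]1CC[C@H](Oc2ccc(F)cc2)CC1` gives 7700 nM in a functional assay on CRL2813 cells (Homo sapiens) for cytotoxicity, read by sulforhodamine B assay, with a stated time of 5 days; a higher number here means a weaker inhibitor, a lower number a stronger inhibitor. Compound 2 `Cc1ccccc1NC(=O)N[C@H]1CC[C@H](Oc2ccc(F)cc2)CC1` reaches only the limit of > 20000 nM in this assay, so only a bound is known for it; this is the limit of > 20000 nM in this assay, at which 1 of the 2 values shown sits. Among the measured compounds shown here, the one measured step, an at least 2.5-fold higher number from compound 1 to compound 2 (0.41 log units; beyond the scatter), shows that exchanging the bromo for a methyl weakened the inhibition. Compound 3 `O=C(Nc1ccccc1C(F)(F)F)N[C@H]1CC[C@H](Oc2ccc(F)cc2)CC1` carries a (trifluoromethyl in place of methyl on an aromatic carbon). For the measured compounds named here, no measured step covers a trifluoromethyl, so the expectation rests on the weak standing of compound 2 alone. Compound 3 is therefore expected to stay weak, with an estimated at least 1.3-fold lower number from compound 2 to compound 3 (0.12 log units; that floor lies within the scatter) and a value near 15000 nM, ranging from 5000 nM to 40000 nM.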

Compound 3, half-maximal inhibitory concentration: > 20000 nM
Compound 3: a limit, no number; the forecaster's own chance of this, stated with the estimate: 45%; middle value at least 1.3-fold (0.12 log units) away from the limit.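

In this assay compound 3 gives > 20000 nM, which is a limit and not a number. The step of an at least 2.5-fold higher number from compound 1 to compound 3 (0.41 log units; beyond the scatter) shows that the loss on leaving bromo is not confined to methyl, as trifluoromethyl at this position also gives a higher number. The step between compound 2 and compound 3 cannot be read, and the series now gathers at one limit: the limit of > 20000 nM in this assay, at which 2 of the 3 values shown sit.

The compounds shown leave open how methyl and trifluoromethyl rank against each other, and whether chloro, iodo or a nitrile at this position would give a readable value.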